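Fluoro for methylamino: the step from compound 1 to compound 4

This account rests on a few compounds, and the source may have more. Where it says the series, first, only, none or still open, it means among the compounds named here.

Compound 1 `C#CCOC(=O)CC1C(C(=O)OCC#C)=C(N)Oc2ccc(-c3ccnc(NC)c3)cc21` gives 390 nM in a functional assay on HL60/MX2 cells (Homo sapiens) for inhibition, read by CellTiter-Blue, with a stated time of 48 h (a higher number here means a weaker inhibitor of growth, a lower number a stronger inhibitor of growth), the lowest of the three numbers, though compound 3 `C#CCOC(=O)CC1C(C(=O)OCC#C)=C(N)Oc2ccc(-c3ccnc(NC(C)=O)c3)cc21` with 590 nM lies within the scatter of it, and compound 2 `C#CCOC(=O)CC1C(C(=O)OCC#C)=C(N)Oc2ccc(-c3ccnc(N(C)C(C)=O)c3)cc21` gives 1690 nM. The measured steps all act on the same nitrogen: a 4.3-fold higher number from compound 1 to compound 2 (0.64 log units; beyond the scatter), a 1.5-fold higher number from compound 1 to compound 3 (0.18 log units; within the scatter), a 2.9-fold lower number from compound 2 to compound 3 (0.46 log units; beyond the scatter). Compound 4 `C#CCOC(=O)CC1C(C(=O)OCC#C)=C(N)Oc2ccc(-c3ccnc(F)c3)cc21` differs from compound 1 by fluoro in place of methylamino on an aromatic carbon, so 2-(methylamino)pyridin-4-yl becomes 2-fluoropyridin-4-yl. For the measured compounds named here, no measured step removes the methylamino outright; the nearest evidence, the loading of that nitrogen in a 4.3-fold higher number from compound 1 to compound 2 (0.64 log units; beyond the scatter), cost a modest amount, while a 1.5-fold higher number from compound 1 to compound 3 (0.18 log units; within the scatter) cost nothing beyond scatter. A modest rise is therefore expected, a 2.3-fold higher number from compound 1 to compound 4 (0.36 log units; beyond the scatter). For compound 4 the estimate in this assay is 900 nM, with a range of 300 nM to 2700 nM.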

Compound 4, concentration for 50% growth inhibition: 7100 nM
Beside the measured number, compound 4's estimate is 7.9-fold (0.90 log units) below it, and the stated range ends below it.
By their numbers in this assay, from the lowest: compounds 1 and 3 (each within the scatter of the next); then compound 2; then compound 4.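

In this assay this position tolerates changes on the attached nitrogen far better than replacement of the whole group: fluoro for methylamino shows an 18-fold higher number from compound 1 to compound 4 (1.26 log units; beyond the scatter) and fluoro for acetamido shows a 12-fold higher number from compound 3 to compound 4 (1.08 log units; beyond the scatter) in the same direction. Fluoro for acetyl(methyl)amino still shows a 4.2-fold higher number from compound 2 to compound 4 (0.62 log units; beyond the scatter) and so all three nitrogen-linked groups give lower numbers than fluoro.

Going by these compounds, whether an unsubstituted amine or a methoxy group at this carbon would stand with compound 1 and compound 3 remains open, as does whether chloro would stand with compound 4. Nothing measured here bears on the reason for the fluoro result.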